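Swapping the side group on the aminated compound

The source may hold more compounds than are shown below. What is called first, only, known or untested is meant among the compounds shown, and "the series" means these compounds.

Measured in a functional assay on A2780 cells (Homo sapiens) for antiproliferative activity, read by CellTiter-Glo, with a stated time of 72 h; a lower number here means a stronger inhibitor, a higher number a weaker inhibitor:
- compound 1 `C[C@@H](c1ccc(NC(=O)N2CC(c3cccnc3)C2)cc1)N1Cc2ccccc2C1=O`: 1.5 nM
- compound 2 `C[C@H](NC(=O)c1cccc(F)c1)c1ccc(NC(=O)N2CC(c3cccnc3)C2)cc1`: 2.3 nM
- compound 3 `C[C@@H](c1ccc(NC(=O)N2CC(c3ccc(N)nc3)C2)cc1)N1Cc2ccccc2C1=O`: 5.9 nM

Among these three, compound 3 has the highest number, 5.9 nM. Compound 4 `C[C@H](NC(=O)c1cccc(F)c1)c1ccc(NC(=O)N2CC(c3ccc(N)nc3)C2)cc1` departs from compound 3 in a single group: a group of 10 heavy atoms (7 carbon, 1 nitrogen, 1 oxygen, 1 fluorine; one six-membered aromatic ring of carbon only) in place of a group of 10 heavy atoms (8 carbon, 1 nitrogen, 1 oxygen; one five-membered non-aromatic ring with 1 hetero atom, one six-membered aromatic ring of carbon only), on a saturated chain carbon bound to an aromatic carbon and a saturated chain carbon. The same exchange gave a 1.5-fold higher number from compound 1 to compound 2 (0.19 log units; within the scatter). The amino in place of hydrogen, which compound 4 carries as well, gave a 3.9-fold higher number from compound 1 to compound 3 (0.59 log units; beyond the scatter). Both steps bear on compound 4, and together they point to a small rise in this assay, not one beyond the scatter. The expected step is a 1.5-fold higher number from compound 3 to compound 4 (0.18 log units; within the scatter). For compound 4 the estimated value is 9 nM, with an expected range from 4 nM to 20 nM.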

Compound 4, half-maximal inhibitory concentration: 7.6 nM
Beside the measured number, compound 4's estimate is 1.2-fold (0.07 log units) above it; low and high end bracket the measured number.
By their numbers in this assay, from the lowest: compounds 1 and 2 (each within the scatter of the next); then compounds 3 and 4 (each within the scatter of the next).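

In this assay the exchange to ((3-fluorophenyl)carbonyl)amino gives a 1.3-fold higher number from compound 3 to compound 4 (0.11 log units; within the scatter) on a second core, a step as small as on the first: the same change on two cores in this assay, a 1.5-fold higher number (0.19 log units; within the scatter) from compound 1 to compound 2 and a 1.3-fold higher number (0.11 log units; within the scatter) from compound 3 to compound 4, 1.2-fold (0.08 log units) apart, within the scatter of two such steps. The amino in place of hydrogen gives a 3.3-fold higher number from compound 2 to compound 4 (0.52 log units; beyond the scatter) on the core of compound 2, close to its size on the core of compound 1: the same change on two cores in this assay, a 3.9-fold higher number (0.59 log units; beyond the scatter) from compound 1 to compound 3 and a 3.3-fold higher number (0.52 log units; beyond the scatter) from compound 2 to compound 4, 1.2-fold (0.08 log units) apart, within the scatter of two such steps. Across these four compounds, then, each change keeps its size whether or not the other is present.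

The compounds shown leave open whether a methylamino in place of the amino would behave alike. Nor do they tell how a chlorine in place of the fluorine, or a longer chain on the carbonyl in place of the fluorophenyl, would fare on either core.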